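This account rests on a few compounds, and the source may have more. Where it says the series, first, only, none or still open, it means among the compounds named here.

For the measured compounds named here, in a functional assay on A549 cells (Homo sapiens) for inhibition, read by MTT assay, with a stated time of 72 h (on this read-out lower numbers stand for stronger inhibition and higher numbers for weaker inhibition), compound 2 `CC1=NN(c2ccccc2)C(=O)[C@]12C(=O)C=CC[C@H]2c1cccc(C)c1` gives 13100 nM, the higher of the two numbers measured so far, while compound 1 `CC1=NN(c2ccccc2)C(=O)[C@@]12C(=O)C=CC[C@H]2c1ccc(C)cc1` gives 6090 nM. Compound 3 `CC1=NN(c2ccccc2)C(=O)[C@@]12C(=O)C=CC[C@H]2c1cccc(C)c1` is a stereoisomer of compound 2: the two compounds have the same atoms and bonds and differ only in configuration as drawn: 1 of 2 stereo elements differ; a stereocentre at a saturated ring carbon is drawn S in compound 2 and R in compound 3. Going by the values given here, no measured pair shows what such a change does in this assay. Compound 3 shares its drawn configuration with compound 1, which stands at 6090 nM, so a small downward move is expected, probably not beyond the scatter. The expected change is a 1.5-fold lower number from compound 2 to compound 3 (0.16 log units; within the scatter). For compound 3 the estimated value is 9000 nM, with a range from 3500 nM to 20000 nM.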

Compound 3, half-maximal inhibitory concentration: 3500 nM
Compound 3: middle estimate off by 2.6-fold (0.41 log units), on the high side, and the stated range covers the measured number.
By their numbers in this assay, from the lowest: compounds 3 and 1 (each within the scatter of the next); then compound 2.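

In this assay, the drawn configuration at this saturated ring carbon now has a measured effect, with R in place of S giving a 3.7-fold lower number from compound 2 to compound 3 (0.57 log units; beyond the scatter), and the cause can be placed in one feature alone: the fact that compounds 2 and 3 differ only in the configuration as drawn. With the configuration held as in compound 3, 3-methylphenyl in place of 4-methylphenyl gives a 1.7-fold lower number from compound 1 to compound 3 (0.24 log units; within the scatter), so this swap is not resolved in this assay. From the compounds shown here alone, it remains open whether the configuration step has the same size with 4-methylphenyl, and how an amine or a methoxy group in place of the methyl would read.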